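Dropping a second methoxy from the aryl ring

The source may hold more compounds than are shown below. What is called first, only, known or untested is meant among the compounds shown, and "the series" means these compounds.

Measured in a functional assay on DU-145 cells (Homo sapiens) for antiproliferative activity, read by MTT assay, with a stated time of 24 h (on this read-out lower numbers stand for stronger inhibition and higher numbers for weaker inhibition), so far:
compound 1 `COc1ccc(C(=O)/C=C/c2cc(-c3cc(OC)c(OC)c(OC)c3)n3nc(-c4ccccc4)cc3n2)cc1`: 25200 nM
compound 2 `COc1ccc(-c2cc(/C=C/C(=O)c3ccc(OC)c(OC)c3)nc3cc(-c4ccccc4)nn23)cc1`: 16400 nM
compound 3 `COc1ccc(C(=O)/C=C/c2cc(-c3ccc(OC)c(OC)c3)n3nc(-c4ccccc4)cc3n2)cc1`: 14600 nM

In this assay compound 3 stands with compound 2 and compound 1 both within the scatter of its own number, so no order among the three can be read. Compound 4 `COc1ccc(C(=O)/C=C/c2cc(-c3ccc(OC)cc3)n3nc(-c4ccccc4)cc3n2)cc1` differs from compound 3 in one place: hydrogen in place of methoxy on an aromatic carbon. Among the compounds with values here, the only measured step that bears on this is the removal of a methoxy from the same aryl ring, a 1.7-fold lower number from compound 1 to compound 3 (0.24 log units; within the scatter), which stayed within the scatter. A methoxy loss of the same kind is therefore expected to give no step beyond the scatter, a 1.0-fold lower number from compound 3 to compound 4 (0.02 log units; within the scatter). Compound 4 is accordingly estimated at 14000 nM, within the range 5000 nM to 40000 nM.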

Compound 4, half-maximal inhibitory concentration: 8500 nM
Compound 4: middle estimate off by 1.6-fold (0.22 log units), on the high side; the measured number falls inside the stated range.
By their numbers in this assay, from the lowest: compounds 4, 3, 2 and 1 (each within the scatter of the next, the first and the last beyond it).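

Taking a second methoxy from this ring gives a 1.7-fold lower number from compound 3 to compound 4 (0.23 log units; within the scatter), and a 1.9-fold lower number from compound 2 to compound 4 (0.29 log units; within the scatter); neither step can be read alone. Taken from the trimethoxy end, however, the change gives a 3.0-fold lower number from compound 1 to compound 4 (0.47 log units; beyond the scatter), the first step on this ring beyond the scatter, and a modest one. Removal of a single methoxy also gives steps of similar size on the two cores: the same change on two cores in this assay, a 1.7-fold lower number (0.24 log units; within the scatter) from compound 1 to compound 3 and a 1.9-fold lower number (0.29 log units; within the scatter) from compound 2 to compound 4, 1.1-fold (0.05 log units) apart, within the scatter of two such steps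

From the compounds shown here alone, whether the remaining methoxy on this ring matters stays open. So does what a hydroxyl, an amine or a fluorine in its place would do.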